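Replacing the acetamidomethyl arm of compound 1

A few compounds are considered here, and "the series" means these few. Any claim that something is new, unique, unknown or untested is made for them only; others in the source may bear on it.

Compound 1 `COc1ccc(-c2nc(CNC(C)=O)sc2-c2ccc(OC)cc2)cc1` is the reference point of the series. Among the measured compounds shown here, in a functional assay with Oryctolagus cuniculus as the target (on this read-out higher numbers stand for weaker inhibition and lower numbers for stronger inhibition), compound 1 gives 15 nM, and this is the only numeric value among the three measured compounds. Compound 2 `COc1ccc(-c2nc(C(=O)N3CCCCC3)sc2-c2ccc(OC)cc2)cc1` gives in this assay only a limit, > 1000 nM. Compound 3 `COc1ccc(-c2nc(C(=O)N3CCN(C(=O)NC(C)C)CC3)sc2-c2ccc(OC)cc2)cc1` likewise gives only a limit in this assay, > 1000 nM. The measured picture is thus set by the limit of > 1000 nM in this assay, at which 2 of the 3 values shown sit. For the measured compounds named here, the one step that can be counted is an at least 66-fold higher number from compound 1 to compound 2 (1.82 log units; beyond the scatter).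

Compound 4 `CCOC(=O)/C=C/c1nc(-c2ccc(OC)cc2)c(-c2ccc(OC)cc2)s1` is not yet measured. It differs from compound 1 as follows: 2-(ethoxycarbonyl)ethenyl in place of acetamidomethyl on an aromatic carbon. Going by the values given here, only the step from compound 1 to compound 2 bears on this change, since both steps remove the acetamidomethyl group; it was large and towards weaker inhibition. The entering group here is, however, an open-chain ester rather than a ring-bearing amide, so the size carried over is uncertain. A step in this assay towards weaker inhibition is expected, a 20-fold higher number from compound 1 to compound 4 (1.30 log units; beyond the scatter). For compound 4 the expected value in this assay is 300 nM, within 40 nM to 3000 nM.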

Compound 4, half-maximal inhibitory concentration: 20 nM
Estimate against measurement, compound 4: 15-fold (1.18 log units) above, outside the stated range (below it).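

Replacing acetamidomethyl with 2-(ethoxycarbonyl)ethenyl on this aromatic carbon gives a step within the scatter in this assay: a 1.3-fold higher number from compound 1 to compound 4 (0.12 log units; within the scatter), so in this pair the hydrogen-bond donor of acetamidomethyl is not needed to keep inhibition. The weak result for compound 2 therefore does not follow simply from losing acetamidomethyl, as an at least 50-fold lower number from compound 2 to compound 4 (1.69 log units; beyond the scatter) shows, although this step starts from a limit and not from a number. The position tolerates two different open-chain arms, while the two ring-bearing carbonyl groups remain at the assay limit: the limit of > 1000 nM in this assay, at which 2 of the 4 values shown sit.

On these data alone, whether the ester, the ethenyl link or both support inhibition stays open; a carboxylic acid or a saturated ethyl link at this position would separate them. Also open, as far as these compounds go, is whether a directly attached carbonyl is tolerated with a small open-chain amide such as a methylamide.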